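Sulfonyl aryl swap in the quinoline-free notes series

The compounds below may be only part of what the source reports. "The series", "measured", "known", "first", "only" and "open" are said of these compounds alone.

Of the compounds shown here, three have been measured in an assay on isolated protein for displacement of a labelled ligand from metabotropic glutamate receptor 5 (Homo sapiens), with a stated time of 60 min, tested at 1 uM; on this read-out lower numbers stand for less inhibition and higher numbers for more inhibition at the one concentration tested (going by the name of the read-out). Compound 1 `O=S(=O)(c1cccc(F)c1)c1cnc2cc(Cl)ccc2c1N1CCC(CO)CC1` gives 71%. Compound 2 `CC1CCN(c2c(S(=O)(=O)c3cccc(Cl)c3)cnc3cc(Cl)ccc23)CC1` gives 92%. Compound 3 `CC1CCN(c2c(S(=O)(=O)c3ccccc3)cnc3cc(F)ccc23)CC1` gives 87%. On these numbers compound 2 carries the highest value of the three; its gap to compound 3 lies within the scatter, so no order between those two can be read, while its gap to compound 1 lies beyond the scatter.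

Compound 4 `CC1CCN(c2c(S(=O)(=O)c3ccc(F)c(F)c3)cnc3cc(Cl)ccc23)CC1` has not been measured. It differs from compound 2 in one place: 3,4-difluorophenyl in place of 3-chlorophenyl on a sulfonyl sulfur. Among the measured compounds shown here, no measured pair in the set isolates this change, so the expectation rests on the spread of the three values, all of which sit in the upper part of the range for this assay.

The step from compound 2 to compound 4 is expected to be small, downward at most, and likely within the scatter, at a number 7 percentage points lower from compound 2 to compound 4 (within the scatter). For compound 4 the estimate is 85%, with a range from 70% to 96%.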

Compound 4, a percentage reported as inhibition, at one concentration (the size of the read-out at that concentration, not a potency): 90%
Compound 4: the middle estimate sits 5 percentage points below what was measured, within the range that was stated.
By their numbers in this assay, from the lowest: compound 1; then compounds 3, 4 and 2 (each within the scatter of the next).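

In this assay, among the compounds shown here, 3,4-difluorophenyl in place of 3-chlorophenyl on a sulfonyl sulfur gives a number 2 percentage points lower from compound 2 to compound 4 (within the scatter) and provides the first pair in this set that differs in one place only. At this position, the two halogenated phenyl groups cannot be told apart on this read-out, so two fluorines can take the place of one chlorine here without a step beyond the scatter. Nothing at hand bears on why the two groups read alike.

As far as these compounds go, both groups are phenyl rings with no hydrogen-bond donors or acceptors, so it remains open how an amine or a carboxylic acid in place of the aryl group on a sulfonyl sulfur would read. From the compounds shown here alone, since this read-out gives a single concentration only, it also remains open whether compound 2 and compound 4 would separate in a full concentration series.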